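Benzothiazole in place of benzoxazole on the fluoro anilide

This account rests on a few compounds, and the source may have more. Where it says the series, first, only, none or still open, it means among the compounds named here.

Compound 2 `O=C(Nc1cc(-c2nc3ccccc3o2)ccc1F)c1cc([N+](=O)[O-])ccc1Cl` has only a limit in an ADME assay on BJ cells (Homo sapiens) for cytotoxicity, with a stated time of 72 h; a higher number here means that more compound is needed for the effect, a lower number that less compound is needed: compound 2 gives > 25000 nM. Compound 1 `O=C(Nc1cc(-c2nc3ccccc3s2)ccc1Cl)c1cc([N+](=O)[O-])ccc1Cl` likewise sits at a limit, giving > 25000 nM in this assay. Both measured values rest at the limit of > 25000 nM in this assay, at which 2 of the 2 values shown sit, so compound 2 stands level with the only other entry. Compound 3 `O=C(Nc1cc(-c2nc3ccccc3s2)ccc1F)c1cc([N+](=O)[O-])ccc1Cl` differs from compound 2 by 1,3-benzothiazol-2-yl in place of 1,3-benzoxazol-2-yl on an aromatic carbon. Compound 1 already carries the 1,3-benzothiazol-2-yl group and shows the same limit. In this assay the expected step from compound 2 to compound 3 is a step that the limit leaves unreadable from compound 2 to compound 3, nothing beyond the scatter. Compound 3 is expected to give 30000 nM, between 15000 nM and 60000 nM, most likely again reported as a limit.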

Compound 3, half-maximal effective concentration: > 25000 nM
Compound 3: only a limit was reported; the forecaster's own chance of this, stated with the estimate: 80%; the middle value is on the limit's open side.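

No new step can be read among compound 1, compound 2 and compound 3, because all three rest at one limit: the limit of > 25000 nM in this assay, at which 3 of the 3 values shown sit. The compounds shown leave open whether 1,3-benzothiazol-2-yl against 1,3-benzoxazol-2-yl, or fluoro against chloro, changes anything in this assay.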